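From Chloro to Methoxy: One Change, One Expected Reading

The source may hold more compounds than are shown below. What is called first, only, known or untested is meant among the compounds shown, and "the series" means these compounds.

Measured so far:
compound 1, `Cc1nc(-c2ccccc2)c(NC(=O)Cn2nnc(-c3ccccc3)n2)s1`: "not active" (no number reported)
compound 2, `Cc1cc(NC(=O)Cn2nnc(-c3cccc(Cl)c3)n2)n(C2CCCCC2)n1`: 89%

Of the compounds shown here, two have been tested in an assay on HEK293 cells for activation of Kir3.1/Kir3.2 (Homo sapiens), read by thallium flux; a lower number here means a smaller maximal response, a higher number a larger maximal response. Compound 1, `Cc1nc(-c2ccccc2)c(NC(=O)Cn2nnc(-c3ccccc3)n2)s1`, came back as "not active" (no number reported), with no number attached to it. Among the measured compounds shown here, compound 2, `Cc1cc(NC(=O)Cn2nnc(-c3cccc(Cl)c3)n2)n(C2CCCCC2)n1`, gives 89% in this assay, and this is the only number in hand, so compound 2 stands alone and no measured step between two numbered compounds exists to lean on.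

Compound 3, `COc1cccc(-c2nnn(CC(=O)Nc3cc(C)nn3C3CCCCC3)n2)c1`, differs from compound 2 in one place: methoxy in place of chloro on an aromatic carbon. Cut one bond further out, the change reads 3-chlorophenyl to 3-methoxyphenyl; the shared core is untouched. For the measured compounds named here, with a single number and no measured step, the size of the move from compound 2 to compound 3 in this assay cannot be read from any precedent. A modest drop, or none beyond the scatter, seems the most likely outcome, though a larger fall cannot be ruled out. Compound 3 is therefore expected to reach about 80%, within a range from 55% to 100%. The expected step is a number 9 percentage points lower from compound 2 to compound 3 (within the scatter).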

Compound 3, largest response reached (Emax), in percent of the reference or control that the assay uses: 76%
Estimate against measurement, compound 3: 4 percentage points above, and the stated range covers the measured number.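

In this assay, among the compounds shown here, putting methoxy in place of chloro on an aromatic carbon gives a number 13 percentage points lower from compound 2 to compound 3 (beyond the scatter), and this is the only measured step between two numbered compounds so far. It shows that this position on the six-membered aromatic ring is not a silent one: exchanging one small group for another at this spot moves the maximal response by more than repeated measurements would normally scatter, although the size of the move is modest and compound 3 still gives 76%. No measurement at hand speaks to what lies behind this step.

As far as these compounds go, a single step cannot show how the response depends on the group at this carbon, so it remains open whether a fluoro, an amine, a carboxylic acid or an ethoxy, which is a longer chain than methoxy, would give a larger or a smaller maximal response than chloro or methoxy. From the compounds shown here alone, it also remains open whether the same exchange of chloro for methoxy would shift the response by a similar amount on a different core, or at another carbon of the same ring.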